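The source may hold more compounds than are shown below. What is called first, only, known or untested is meant among the compounds shown, and "the series" means these compounds.

Measured in a functional assay on ECa-109 cells for inhibition, with ECa-109 cell line (Homo sapiens) as the target, read by sulforhodamine B assay; a higher number here means a weaker inhibitor, a lower number a stronger inhibitor:
Compound 1 `O=C1C(N2CCCCC2)=CC(=O)c2c1nc1n2[C@H]2OC[C@@H](O)[C@H]2OC1`: > 8000 nM, a limit
Compound 2 `O=C1C(Nc2ccc(C(F)(F)F)cc2)=CC(=O)c2c1nc1n2[C@H]2OC[C@@H](O)[C@H]2OC1`: 2250 nM
Compound 3 `O=C1C(NCc2ccccc2)=CC(=O)c2c1nc1n2[C@H]2OC[C@@H](O)[C@H]2OC1`: > 8000 nM, a limit

Compound 3 has no number, only a limit, and stands at the limit of > 8000 nM in this assay, at which 2 of the 3 values shown sit.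

The move to compound 4 `O=C1C(Nc2cccc(Cl)c2)=CC(=O)c2c1nc1n2[C@H]2OC[C@@H](O)[C@H]2OC1` puts 3-chlorophenyl in place of benzyl on an amine nitrogen.

The step that bears most on this is an at least 3.5-fold higher number from compound 2 to compound 3 (0.55 log units; beyond the scatter), which also swaps a phenyl group for benzyl on that nitrogen. The other step gives no size: a step that the two limits leave unreadable from compound 1 to compound 3.

Compound 4 reverses that kind of change, so a move of at least modest size toward a stronger inhibitor is expected. The expected change is an at least 2.6-fold lower number from compound 3 to compound 4 (0.42 log units; beyond the scatter). For compound 4 the estimate is 3000 nM, with an expected range of 1200 nM to 8000 nM.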

Compound 4, half-maximal inhibitory concentration: 3080 nM
The estimate for compound 4 lay 1.0-fold (0.01 log units) below the measured number; the range from low to high includes it.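

In this assay, the gain from a phenyl ring carried directly on the amine nitrogen now appears with a second substituent, 3-chlorophenyl (an at least 2.5-fold lower number from compound 3 to compound 4 (0.41 log units; beyond the scatter)), and the same group also separates from the piperidin-1-yl of compound 1 (an at least 2.5-fold lower number from compound 1 to compound 4 (0.41 log units; beyond the scatter)). The ring substituent itself makes no readable difference in this pair (a 1.4-fold higher number from compound 2 to compound 4 (0.14 log units; within the scatter)). Both gains are minimum sizes only, as compound 1 and compound 3 each give a limit and not a number: the limit of > 8000 nM in this assay, at which 2 of the 4 values shown sit.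

Open, as far as these compounds go, is whether an unsubstituted phenyl, or a phenyl carrying a carboxylic acid or an amine, on this nitrogen stays in the same range.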